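The source may report more compounds than this note shows. Statements on the series, on what has been measured and on what is new or still open speak of the compounds shown alone.

Measured compounds:
- compound 1, `COc1cc(C(=O)/C=C/c2cn(-c3ccccc3)nc2-c2ccsc2)cc(OC)c1OC`: 3600 nM
- compound 2, `O=C(/C=C/c1cn(-c2ccccc2)nc1-c1cccnc1)c1ccsc1`: 1700 nM

In a functional assay on Huh-7 cells (Homo sapiens) for inhibition, read by sulforhodamine B assay, with a stated time of 72 h (a lower number here means a stronger inhibitor, a higher number a weaker inhibitor), compound 2 holds the lower of the two numbers; compound 1 sits higher, and that gap lies beyond the scatter. Among the measured compounds shown here, nothing more can be read into the pair, since the two differ in more than one place and no single step between them is worked out.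

Compound 3, `O=C(/C=C/c1cn(-c2ccccc2)nc1-c1cccnc1)c1cc[nH]c1`, is not yet measured in this assay. It differs from compound 2 by 1H-pyrrol-3-yl in place of thiophen-3-yl on a carbonyl carbon. With no measured step of this kind in the series, there is no basis for a direction; the change is expected to give no step beyond the scatter, with the estimate kept wide. Compound 3 is therefore expected at 2500 nM, with a range of 800 nM to 8000 nM, which corresponds to an expected step of a 1.5-fold higher number from compound 2 to compound 3 (0.17 log units; within the scatter).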

Compound 3, half-maximal inhibitory concentration: 3300 nM
Compound 3: middle estimate off by 1.3-fold (0.12 log units), on the low side; the range from low to high includes it.
By their numbers in this assay, from the lowest: compounds 2, 3 and 1 (each within the scatter of the next, the first and the last beyond it).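

At the carbonyl carbon, 1H-pyrrol-3-yl in place of thiophen-3-yl gives a 1.9-fold higher number from compound 2 to compound 3 (0.29 log units; within the scatter) in this assay, the first single-place step available in this series. The entering group has 1 hydrogen-bond donor and 0 hydrogen-bond acceptors, the leaving group 0 and 1, yet the two compounds cannot be told apart in this read-out, so this position tolerates the exchange within the scatter on this core. No supporting data bear on this result.

Open, on these data alone, is whether a group of another kind on the carbonyl carbon, such as a dimethylamine forming an amide or a longer alkyl chain, would move the number beyond the scatter. Also open, as far as these compounds go, is whether the same exchange would read alike on the rest of the molecule carried by compound 1.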